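Swapping the aryl arm on the chain substituent

The source may hold more compounds than are shown below. What is called first, only, known or untested is meant among the compounds shown, and "the series" means these compounds.

Two compounds in the series have numbers in a functional assay on H4 cells for agonist activity at growth hormone secretagogue receptor type 1 (Homo sapiens), read by FLIPR; a lower number here means that less compound is needed, a higher number that more compound is needed for the effect. Compound 1 `CN(c1ccccc1CCCn1nnnc1[C@@H](COCc1ccccc1)NC(=O)C(C)(C)N)S(C)(=O)=O` gives 14 nM in this assay, the lower of the two. Compound 2 `CC(C)(N)C(=O)N[C@H](COCc1ccccc1)c1nnn(CC#N)n1` differs from compound 1 in several places. In this assay compound 2 gives 1520 nM. Within the data shown here, the gap between compound 1 and compound 2 lies beyond the scatter, and no single step between measured compounds is available. Compound 3 `COC(=O)CCCn1nnnc1[C@@H](COCc1ccccc1)NC(=O)C(C)(C)N` has not been measured. It differs from compound 1 in one place: methoxycarbonyl in place of 2-(methyl(methylsulfonyl)amino)phenyl on a saturated chain carbon, three bonds along the chain from an aromatic nitrogen. The group that leaves carries the only aromatic ring outside the shared core on that chain; the group that enters carries no ring. On these two numbers alone, the step from compound 1 to compound 3 is expected to raise the number in this assay by a 14-fold higher number from compound 1 to compound 3 (1.15 log units; beyond the scatter), beyond the scatter. Compound 3 is therefore estimated at 200 nM in this assay, with a range from 40 nM to 1000 nM.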

Compound 3, half-maximal effective concentration: 55 nM
For compound 3 the middle estimate is 3.6-fold (0.56 log units) above the measured one; the measured number falls inside the stated range.
By their numbers in this assay, from the lowest: compound 1; then compound 3; then compound 2.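

In this assay, the change at this saturated chain carbon, three bonds along the chain from an aromatic nitrogen, gives a 3.9-fold higher number from compound 1 to compound 3 (0.59 log units; beyond the scatter), a modest step that lies beyond the scatter. The aromatic ring on this chain is therefore not a requirement for activity: compound 3, with ring-free methoxycarbonyl, still gives 55 nM, although 2-(methyl(methylsulfonyl)amino)phenyl gives the lower number. No measurement bears on what lies behind this difference.

Still open, as far as these compounds go, is how the step divides between the phenyl ring and its methyl(methylsulfonyl)amino part, a question that an unsubstituted phenyl at this place would address. A carboxylic acid or a primary amide in place of methoxycarbonyl would show whether the number for the ring-free arm depends on the ester itself.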